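From 4-hydroxypiperidin-1-yl to 3-carboxypiperidin-1-yl on a sulfonyl sulfur

This account rests on a few compounds, and the source may have more. Where it says the series, first, only, none or still open, it means among the compounds named here.

Of the compounds shown here, two with a shared core have been measured in an ADME assay on Vero cells (Chlorocebus sabaeus) for cytotoxicity, read by MTT assay; on this read-out higher numbers stand for lower toxicity in this test and lower numbers for higher toxicity in this test. Going by the values given here, compound 2 `Cn1nc(C(F)(F)F)cc1C(=O)Nc1ccc(S(=O)(=O)N2CCC(O)CC2)cc1` gives 274000 nM, the only exact number available so far. Compound 1 `Cn1nc(C(F)(F)F)cc1C(=O)Nc1ccc(S(=O)(=O)N2CCC[C@H]2C(=O)O)cc1` reads > 300000 nM, which is a limit of the assay and not a number. Compound 3 `Cn1nc(C(F)(F)F)cc1C(=O)Nc1ccc(S(=O)(=O)N2CCCC(C(=O)O)C2)cc1` is the next to be measured, and it differs from compound 2 by one exchange: 3-carboxypiperidin-1-yl in place of 4-hydroxypiperidin-1-yl on a sulfonyl sulfur. In words, 3-carboxypiperidin-1-yl replaces 4-hydroxypiperidin-1-yl on a sulfonyl sulfur. Among the compounds with values here, only one measured step bears on this, since compound 1 also carries a carboxy-bearing ring, 2-carboxypyrrolidin-1-yl: an at least 1.0-fold lower number from compound 1 to compound 2 (0.03 log units; that floor lies within the scatter). No step beyond the scatter is therefore expected in this assay, and no direction can be assigned. The expected step, a 1.1-fold higher number from compound 2 to compound 3 (0.04 log units; within the scatter), is estimated to remain within the scatter. Compound 3 is expected at about 300000 nM, with an estimated range of 170000 nM to 500000 nM.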

Compound 3, half-maximal cytotoxic concentration: > 300000 nM
Compound 3 ended at the assay's limit; the forecaster's own chance of this, stated with the estimate: 60%; the middle value lies on the limit itself.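

In this assay, 3-carboxypiperidin-1-yl in place of 4-hydroxypiperidin-1-yl on a sulfonyl sulfur gives an at least 1.0-fold higher number from compound 2 to compound 3 (0.03 log units; that floor lies within the scatter), so this change shows no step beyond the scatter, though a larger true step is not excluded. For compound 3, the reading of > 300000 nM is a limit and not a number. The six-membered 3-carboxypiperidin-1-yl now ends at the same limit as the five-membered 2-carboxypyrrolidin-1-yl of compound 1, which the earlier compounds could not show: the limit of > 300000 nM in this assay, at which 2 of the 3 values shown sit.

On these data alone, the step between compound 1 and compound 3 cannot be read, and how far either compound lies past the limit remains open. Also open, as far as these compounds go, is whether a primary amine or a longer chain carrying a carboxylic acid at this place on the sulfonyl sulfur would give a readable number.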